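Shifting the halogen benzyl to a methyl benzyl in cytotoxicity

The compounds below may be only part of what the source reports. "The series", "measured", "known", "first", "only" and "open" are said of these compounds alone.

Three compounds share one core and differ only in the group on the saturated chain carbon bound to an aromatic nitrogen. Compound 1 `COC(=O)c1ccc(NCc2cncn2Cc2cccc(C)c2)cc1-c1ccccc1` carries a 3-methylphenyl there; in a toxicity assay on NIH3T3 cells (Mus musculus) for cytotoxicity, read by resazurin assay (a lower number here means that less compound is needed, a higher number that more compound is needed for the effect), compound 1 gives only a limit of the assay, > 10000 nM. Compound 2 `COC(=O)c1ccc(NCc2cncn2Cc2ccccc2Br)cc1-c1ccccc1` carries a 2-bromophenyl, and in this assay compound 2 gives 10000 nM. Compound 3 `COC(=O)c1ccc(NCc2cncn2Cc2cccc(Cl)c2)cc1-c1ccccc1` carries a 3-chlorophenyl, and for it too only a limit is known: compound 3 gives > 10000 nM.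

The step of a number no higher from compound 1 to compound 2 (the limit leaves the size open) and the step of a number no lower from compound 2 to compound 3 (the limit leaves the size open) are both bounded on one side only, and the step that the two limits leave unreadable from compound 1 to compound 3 cannot be read at all, since (the limit of > 10000 nM in this assay, at which 2 of the 3 values shown sit). All three measured values thus sit at or beside the same ceiling.

Compound 4 `COC(=O)c1ccc(NCc2cncn2Cc2ccc(C)cc2)cc1-c1ccccc1` is the next step: 4-methylphenyl in place of 3-chlorophenyl on a saturated chain carbon bound to an aromatic nitrogen. Within the data shown here, no measured step shows a change in this assay that clears the scatter, so compound 4 is expected to stay at the ceiling as well, with an expected step that the limit leaves unreadable from compound 3 to compound 4. For compound 4 the estimated value is 12000 nM, with an expected range from 5000 nM to 30000 nM.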

Compound 4, half-maximal effective concentration: 50000 nM
The estimate for compound 4 lay 4.2-fold (0.62 log units) below the measured number; the measured number lies above the stated range.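

Among these compounds, replacing 2-bromophenyl with 4-methylphenyl on a saturated chain carbon bound to an aromatic nitrogen gives, in this assay, a 5.0-fold higher number from compound 2 to compound 4 (0.70 log units; beyond the scatter), the first step at this position whose size can be read. This shows that the group at this position can move the number beyond the scatter, with more of compound 4 than of compound 2 needed for the effect. The steps to compound 4 from compound 1 and from compound 3 cannot be read, since each of those two compounds is known only as a limit: the limit of > 10000 nM in this assay, at which 2 of the 4 values shown sit.

The step from compound 2 to compound 4 changes both the substituent and its place on the phenyl ring, so the compounds shown do not separate the effect of bromo versus methyl from that of the 2-position versus the 4-position. Going by these compounds, it also remains open how the number would respond to an amine or a carboxylic acid on that phenyl ring.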